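The compounds below may be only part of what the source reports. "The series", "measured", "known", "first", "only" and "open" are said of these compounds alone.

Measured compounds and their values:
- Compound 1 `CSc1ncc(C2C(C(=O)OCCCc3ccccc3)=C(C)NC(C)=C2C(=O)OCCCc2ccccc2)n1Nc1ccccc1`: 3.15 nM
- Compound 2 `CCOC(=O)C1=C(C)NC(C)=C(C(=O)OC(C)C)C1c1cnc(SC)n1Nc1ccccc1`: 3.22 nM
- Compound 3 `CCOC(=O)C1=C(C)NC(C)=C(C(=O)OCCOC)C1c1cnc(SC)n1Nc1ccccc1`: 2.91 nM

In an assay on isolated protein (strain albino) for antagonist activity at Voltage-dependent L-type calcium channel subunit alpha-1C (Cavia porcellus) (a lower number here means a stronger inhibitor, a higher number a weaker inhibitor), compound 2 gives 3.22 nM, the highest of the three numbers, but the gaps to compound 1 and compound 3 are both within the scatter, so the three measured compounds cannot be told apart on this read-out. Compound 4 `CSc1ncc(C2C(C(=O)OCCCc3ccccc3)=C(C)NC(C)=C2C(=O)OC(C)C)n1Nc1ccccc1` is obtained from compound 2 by the change (benzyl in place of hydrogen on a saturated chain carbon, two bonds along the chain from an oxygen next to a carbonyl group), so the ethyl ester of compound 2 becomes a 3-phenylpropyl ester while the isopropyl ester is kept. Within the data shown here, the only measured step at an ester oxygen is a 1.1-fold lower number from compound 2 to compound 3 (0.04 log units; within the scatter), which did nothing beyond the scatter. Among the measured compounds shown here, compound 1, carrying 3-phenylpropyl on both ester oxygens, gives 3.15 nM, essentially the same number as compound 2; no single-change step links those two, but their values show that 3-phenylpropyl esters are tolerated at this level. The expectation is therefore a step of about a 1.0-fold lower number from compound 2 to compound 4 (0.02 log units; within the scatter), nothing beyond the scatter. Compound 4 is expected to give 3.1 nM, within the range 1.8 nM to 5.5 nM.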

Compound 4, half-maximal inhibitory concentration: 6.22 nM
Compound 4: middle estimate off by 2.0-fold (0.30 log units), on the low side; measured number above the stated range.
By their numbers in this assay, from the lowest: compounds 3, 1, 2 and 4 (each within the scatter of the next, the first and the last beyond it).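

In this assay, the two new steps are a 1.9-fold higher number from compound 2 to compound 4 (0.29 log units; within the scatter) and a 2.0-fold higher number from compound 1 to compound 4 (0.30 log units; within the scatter). Thus, on a shared core, adding benzyl to turn ethyl into 3-phenylpropyl, and exchanging 3-phenylpropyl for isopropyl on the other ester oxygen, each gives a single-change step that stays within the scatter, so neither change can be read as altering the number. Nothing shown explains the size of these steps.

Still open, from the compounds shown here alone, is whether any group on these ester oxygens can move the number beyond the scatter, for example a 2-aminoethyl chain, a carboxylic acid in place of the ester, or a chain longer than 3-phenylpropyl. Going by these compounds, it is also open whether the phenyl ring of 3-phenylpropyl matters, which a plain propyl ester would test.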